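A few compounds are considered here, and "the series" means these few. Any claim that something is new, unique, unknown or untested is made for them only; others in the source may bear on it.

Compound 1 `CS(=O)(=O)Oc1ccc2c3c(c(=O)oc2c1)CCCCCC3`: 24500 nM
Compound 2 `O=c1oc2cc(OS(=O)(=O)C3CC3)ccc2c2c1CCCCCC2`: 10500 nM

These two compounds share one core and differ only in the group on the sulfonyl sulfur. In an ADME assay on RAW264.7 cells (Mus musculus) for cytotoxicity, read by MTT assay, with a stated time of 24 h (a higher number here means a weaker inhibitor, a lower number a stronger inhibitor), compound 2 has the lower number of the pair, at 10500 nM. The unmeasured compound 3 `O=c1oc2cc(OS(=O)(=O)c3ccc(C(F)(F)F)cc3)ccc2c2c1CCCCCC2` keeps the same core and changes the same place, with 4-(trifluoromethyl)phenyl in place of cyclopropyl on a sulfonyl sulfur. Among the compounds with values here, only one measured step bears on this change: a 2.3-fold lower number from compound 1 to compound 2 (0.37 log units; beyond the scatter). That step, with cyclopropyl in place of methyl at the same place, was modest but beyond the scatter. It is a single example with a different incoming group, and no aromatic ring on this sulfur has been measured yet. It therefore suggests a direction better than a size, and another modest move towards a lower number is expected in this assay. The estimated change is a 1.6-fold lower number from compound 2 to compound 3 (0.21 log units; within the scatter). For compound 3 the expected value is 6500 nM, with an estimated range from 2500 nM to 16000 nM.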

Compound 3, half-maximal inhibitory concentration: > 100000 nM
Compound 3 gave a limit, no number; the forecaster's own chance of this, stated with the estimate: 10%; middle value at least 15-fold (1.18 log units) away from the limit.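

In this assay compound 3 gives a limit and not a number: the limit of > 100000 nM in this assay, at which 1 of the 3 values shown sits. This position does not respond in a single direction: cyclopropyl in place of methyl had lowered the number, but 4-(trifluoromethyl)phenyl on the same sulfonyl sulfur moves it the other way, with an at least 9.5-fold higher number from compound 2 to compound 3 (0.97 log units; beyond the scatter) and an at least 4.0-fold higher number from compound 1 to compound 3 (0.61 log units; beyond the scatter). The step to the aromatic group is also larger than the earlier step between the two small groups, so that earlier step gave a poor guide to what this much bigger group would do.

Compound 3 brings in a six-membered aromatic ring and a trifluoromethyl group together, so the compounds shown cannot tell which of the two goes with the higher number; a plain phenyl ring on the sulfur would separate them. As far as these compounds go, it also stays open how a group of intermediate size, such as a butyl chain, would behave at this position, and whether the order of these three compounds would hold in any other assay.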